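Flat cytotoxicity values in a small series

A few compounds are considered here, and "the series" means these few. Any claim that something is new, unique, unknown or untested is made for them only; others in the source may bear on it.

- compound 1 `COc1cc(/C=C/C(=O)C2=C(/C=C/c3ccc(O)c(OC)c3)NC(=O)NC2c2ccc(O)cc2)ccc1O` in a functional assay on HeLa cells (Homo sapiens) for cytotoxicity, read by MTT assay, with a stated time of 48 h (a lower number here means a stronger inhibitor, a higher number a weaker inhibitor), gives 25000 nM
- compound 2 `COc1cc(/C=C/C(=O)C2=C(/C=C/c3ccc(O)c(OC)c3)NC(=O)NC2c2c(Cl)cccc2Cl)ccc1O` gives 25000 nM
- compound 3 `COc1cc(/C=C/C(=O)C2=C(/C=C/c3ccc(O)c(OC)c3)NC(=S)NC2c2ccccc2)ccc1O` gives 25000 nM

Level with compound 1 and compound 2, compound 3 stands at 25000 nM in this assay and so gives no separation within the series. Compound 4 `COc1cc(/C=C/C(=O)C2=C(/C=C/c3ccc(O)c(OC)c3)NC(=S)NC2c2ccccc2O)ccc1O` differs from compound 3 by one change, phenyl to 2-hydroxyphenyl, with hydroxy in place of hydrogen on an aromatic carbon, ortho to a large group hydroxy in place of hydrogen on an aromatic carbon and nothing else altered.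

Within the data shown here, no step has been measured from compound 3 itself, so the evidence is thin. The nearest measured change is 2,6-dichlorophenyl in place of 4-hydroxyphenyl on a saturated ring carbon, and it shows no change at the digits printed from compound 1 to compound 2 (within the scatter) in this assay. On that basis, no step beyond the scatter is expected.

The expected step is a 1.1-fold lower number from compound 3 to compound 4 (0.06 log units; within the scatter) according to this estimate.

For compound 4 the estimated value is 22000 nM, with an expected range from 9000 nM to 30000 nM in this assay.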

Compound 4, half-maximal inhibitory concentration: 25000 nM
Compound 4: the middle estimate sits 1.1-fold (0.06 log units) below what was measured; the measured number falls inside the stated range.
By their numbers in this assay, from the lowest: compounds 1, 2, 3 and 4 (each within the scatter of the next).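

In this assay, placing hydroxy on an aromatic carbon, ortho to a large group, gives no change at the digits printed from compound 3 to compound 4 (within the scatter). This is the first single change shown on the unsubstituted phenyl of compound 3, and it shows that adding hydroxy at this position does not separate compound 4 from its parent. Nothing available accounts for this flat result, and no cause can be assigned to it.

Going by these compounds, whether an amine, a carboxylic acid or a methoxy group on the same aromatic carbon would shift the value remains open. On these data alone, with all four compounds sharing one printed value in this assay, it is also open whether any change to the aryl group can separate members.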